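Ring-closing the basic amine on a benzothiazole urea side chain

The source may hold more compounds than are shown below. What is called first, only, known or untested is meant among the compounds shown, and "the series" means these compounds.

Measured compounds:
compound 1, `COc1ncc(-c2ccc3nc(NC(=O)NCCN(C)C)sc3c2)cc1NS(=O)(=O)c1ccc(F)cc1`, 1020 nM
compound 2, `COc1ncc(-c2ccc3nc(NC(=O)NC4CC4)sc3c2)cc1NS(=O)(=O)c1ccc(F)cc1`, 520 nM

Of the compounds shown here, two sharing one core have been measured in a functional assay on U-87MG ATCC cells for antiproliferative activity against U-87 MG (Homo sapiens), read by MTT assay, with a stated time of 72 h; a higher number here means a weaker inhibitor, a lower number a stronger inhibitor. Compound 1, `COc1ncc(-c2ccc3nc(NC(=O)NCCN(C)C)sc3c2)cc1NS(=O)(=O)c1ccc(F)cc1`, gives 1020 nM, the highest of the two numbers; its nearest neighbour is compound 2, `COc1ncc(-c2ccc3nc(NC(=O)NC4CC4)sc3c2)cc1NS(=O)(=O)c1ccc(F)cc1`, which gives 520 nM. Among the compounds with values here, the only measured step, a 2.0-fold lower number from compound 1 to compound 2 (0.29 log units; within the scatter), exchanges the whole side chain on the amide-type nitrogen and lands within the scatter, so the two values are treated as equivalent.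

Compound 3, `COc1ncc(-c2ccc3nc(NC(=O)NCCN4CCCCC4)sc3c2)cc1NS(=O)(=O)c1ccc(F)cc1`, keeps the two-carbon chain of compound 1 and alters only its end: piperidin-1-yl in place of dimethylamino on a saturated chain carbon, two bonds along the chain from an amide-type nitrogen. Within the data shown here, no measured pair isolates this change, so the step from compound 1 to compound 2 is the only guide, and it shows that a larger reshaping of this side chain left the number within the scatter. The expected step of a 1.1-fold lower number from compound 1 to compound 3 (0.05 log units; within the scatter) is therefore small, with no direction beyond the scatter. Compound 3 is estimated at 900 nM, in a range from 400 nM to 2000 nM.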

Compound 3, half-maximal inhibitory concentration: 750 nM
Beside the measured number, compound 3's estimate is 1.2-fold (0.08 log units) above it; measured number inside the range.
By their numbers in this assay, from the lowest: compounds 2, 3 and 1 (each within the scatter of the next).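

In this assay, piperidin-1-yl in place of dimethylamino gives a 1.4-fold lower number from compound 1 to compound 3 (0.13 log units; within the scatter), which shows that this place on a saturated chain carbon, two bonds along the chain from an amide-type nitrogen, takes a six-membered non-aromatic ring with no difference that the assay can separate from the scatter. The comparison with the cyclopropyl compound gives a 1.4-fold higher number from compound 2 to compound 3 (0.16 log units; within the scatter), so the 2-(piperidin-1-yl)ethyl group also cannot be told apart from cyclopropyl on that nitrogen, and all three side chains shown remain equivalent by these numbers. No accompanying measurement bears on this result, so it offers no explanation for it.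

The compounds shown leave open whether a morpholine or a piperazine at the end of the two-carbon chain, or a longer chain carrying the same piperidine, would move the number beyond the scatter. They also leave open whether a carboxylic acid in place of the amine would do so, and how any of these side chains would behave with a different group elsewhere on the shared core.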